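Nitro for Pyrrolidin-1-yl on a Shared Core

The compounds below may be only part of what the source reports. "The series", "measured", "known", "first", "only" and "open" are said of these compounds alone.

Compound 1, `COc1ccc(C(=O)/C=C/c2ccc(-c3ccccc3)cc2)c2c1C=CC(C)(C)O2`, gives a limit of > 10000 nM in a functional assay on HCT-116 cells (Homo sapiens) for antiproliferative activity, read by MTT assay, with a stated time of 24 h; on this read-out higher numbers stand for weaker inhibition and lower numbers for stronger inhibition. Compound 2, `COc1ccc(C(=O)/C=C/c2ccc(N3CCCC3)cc2)c2c1C=CC(C)(C)O2`, gives 8590 nM in this assay.

Compound 2 holds the only number shown; the other entry is a limit (the limit of > 10000 nM in this assay, at which 1 of the 2 values shown sits). Compound 3, `COc1ccc(C(=O)/C=C/c2ccc([N+](=O)[O-])cc2)c2c1C=CC(C)(C)O2`, differs from compound 2 by nitro in place of pyrrolidin-1-yl on an aromatic carbon. Within the data shown here, the one measured step, an at least 1.1-fold lower number from compound 1 to compound 2 (0.06 log units; that floor lies within the scatter), begins at a limit and sits within the scatter, so it gives little guidance on this change. Compound 3 is therefore expected to remain close to compound 2, with a 1.0-fold higher number from compound 2 to compound 3 (0.02 log units; within the scatter) as the estimated step. The estimate for compound 3 is 9000 nM, expected between 3000 nM and 30000 nM.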

Compound 3, half-maximal inhibitory concentration: 8880 nM
Compound 3: middle estimate off by 1.0-fold (0.01 log units), on the high side, and the stated range covers the measured number.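

At this position in this assay, nitro, which has no ring, reads the same as pyrrolidin-1-yl, a five-membered non-aromatic ring, with a 1.0-fold higher number from compound 2 to compound 3 (0.01 log units; within the scatter). Two groups with different atoms and ring content therefore cannot be told apart on this read-out. The other comparison, an at least 1.1-fold lower number from compound 1 to compound 3 (0.05 log units; that floor lies within the scatter), starts from a limit and its floor lies within the scatter, so it gives no ordering: the limit of > 10000 nM in this assay, at which 1 of the 3 values shown sits.

Going by these compounds, what a carboxylic acid or a primary amine would give on this aromatic carbon remains open. Also open, on these data alone, is whether any group here can move the number beyond the scatter.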